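The compounds below may be only part of what the source reports. "The series", "measured", "known", "first", "only" and "open" are said of these compounds alone.

Measured compounds:
compound 1 `NC(=S)NNc1ncnc2c1cnn2-c1ccccc1`: > 200000 nM
compound 2 `NC(=S)NNc1ncnc2c1cnn2-c1ccc(Cl)cc1`: > 200000 nM
compound 3 `Cc1ccc(-n2ncc3c(NNC(N)=S)ncnc32)cc1`: "nd(insoluble)" (no result reported)

The three compounds share one core and differ only in the group on the phenyl ring. In an ADME assay on cells (Peritoneal macrophage, Mus musculus, strain Swiss) for cytotoxicity, read by MTT assay, with a stated time of 48 h (a higher number here means that more compound is tolerated, a lower number that less compound is tolerated), compound 1 gives only a limit of the assay, > 200000 nM. Compound 2 likewise gives only a limit, > 200000 nM. The step that the two limits leave unreadable from compound 1 to compound 2 is therefore not readable. Compound 3 gave no number at all in this assay, being recorded as "nd(insoluble)" (no result reported), so it stands apart from the other two, which both sit at the limit of > 200000 nM in this assay, at which 2 of the 3 values shown sit.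

Compound 4 `NC(=S)NNc1ncnc2c1cnn2-c1ccc(C(F)(F)F)cc1` follows from compound 3 by trifluoromethyl in place of methyl on an aromatic carbon. Going by the values given here, no measured step touches this change, and the single measured step between compound 1 and compound 2 is unreadable because of the limit of > 200000 nM in this assay, at which 2 of the 3 values shown sit. What can be said is that every compound with a number in this assay reached the limit. For compound 4 the expectation is therefore that this assay will again report only a limit rather than a number, and the estimate is 200000 nM, within a range from 80000 nM to 400000 nM.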

Compound 4, concentration lethal to 50% of the cells: > 200000 nM
Compound 4 gave a limit, no number; the forecaster's own chance of this, stated with the estimate: 70%; the middle value sits exactly at the limit.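

Going by these compounds alone, no step among compound 1, compound 2 and compound 4 can be read in this assay, because all three give only the same limit: the limit of > 200000 nM in this assay, at which 3 of the 4 values shown sit. The compounds shown leave open whether chloro, trifluoromethyl or hydrogen on the phenyl ring makes any difference to tolerance, and where compound 3 stands.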